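Carbamoyl removal from compound 1: working notes

The source may hold more compounds than are shown below. What is called first, only, known or untested is meant among the compounds shown, and "the series" means these compounds.

Within the data shown here, in a functional assay on A549 cells (Homo sapiens) for cytotoxicity (a higher number here means a weaker inhibitor, a lower number a stronger inhibitor), compound 1 `C=C/C=C\[C@H](C)[C@H](OC(N)=O)[C@@H](C)[C@H](O)[C@@H](C)C/C(C)=C\[C@H](C)[C@H]1OC(=O)C=C[C@@H]1C` gives 6770 nM and this is the only number so far. Compound 2 `CCCC[C@H](C)[C@H](OC(N)=O)[C@@H](C)[C@H](OC(C)=O)[C@@H](C)C/C(C)=C\[C@H](C)[C@@H](OC(C)=O)[C@@H](C)CCCC[C@@H]1OC(=O)[C@H](C)[C@@H](OC(C)=O)[C@H]1C` has the entry "not determined" (no result reported) and offers no comparison. Compound 3 `C=C/C=C\[C@H](C)[C@H](O)[C@@H](C)[C@H](O)[C@@H](C)C/C(C)=C\[C@H](C)[C@H]1OC(=O)C=C[C@@H]1C` has hydrogen in place of carbamoyl on an oxygen on a saturated carbon, carbamoyloxy to hydroxy hydrogen in place of carbamoyl on an oxygen on a saturated carbon and is still to be measured. Among the measured compounds shown here, no measured step bears on this change, so the expectation is tentative. A modest loss of strength in this assay is expected, with the estimated step of a 2.1-fold higher number from compound 1 to compound 3 (0.32 log units; beyond the scatter) as the working figure. The estimate for compound 3 is 14000 nM with an expected range from 5000 nM to 40000 nM in this read-out.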

Compound 3, half-maximal inhibitory concentration: > 12700 nM
Compound 3 was reported as a limit; the forecaster's own chance of this, stated with the estimate: 20%; the middle value does not contradict the limit.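

Compound 3 is reported only as a limit in this assay: the limit of > 12700 nM in this assay, at which 1 of the 3 values shown sits. Among these compounds, this is the first reading of a change at this oxygen on a saturated carbon: carbamoyloxy to hydroxy gives an at least 1.8-fold higher number from compound 1 to compound 3 (0.27 log units; that floor lies within the scatter). The hydroxy shows no gain in strength, but the size of any loss stays unfixed.

The compounds shown leave open how a methyl ether or an amine in this place would read in this assay. As far as these compounds go, whether the same change reads alike on a different core also stays open.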